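The source may hold more compounds than are shown below. What is called first, only, known or untested is meant among the compounds shown, and "the series" means these compounds.

Measured so far:
- compound 1, `CC(C)N(Cc1cccc(OCCCCCC(=O)O)c1)C(=O)c1ccc(-c2cccc3ccccc23)cc1`, with > 26000 nM in an ADME assay on Raji cells (Homo sapiens) for cytotoxicity, read by CellTiter-Glo and resazurin assay, with a stated time of 72 h; on this read-out higher numbers stand for an effect only at larger amounts of compound and lower numbers for an effect already at smaller amounts
- compound 2, `CC(C)N(Cc1cccc(OCCCCCC(=O)O)c1)C(=O)c1ccc(-c2cccc(-c3ccccc3)c2)cc1`, with > 26000 nM in this assay
- compound 3, `CCOC(=O)CCCCCOc1cccc(CN(C(=O)c2ccc(-c3cccnc3)cc2)C(C)C)c1`, with > 26000 nM in this assay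

All three of these values are limits of the assay, not numbers. Compound 3 sits at a limit, > 26000 nM, and so it stands at the same edge as the two other measured compounds, as the limit of > 26000 nM in this assay, at which 3 of the 3 values shown sit, records. Among the measured compounds shown here, the only step that was measured between two compounds, a step that the two limits leave unreadable from compound 1 to compound 2, is unreadable for the same reason, since both ends are limits.

Compound 4, `CCOC(=O)CCCCCOc1cccc(CN(C(=O)c2ccc(-c3cccc(OC)c3)cc2)C(C)C)c1`, is not yet measured. It differs from compound 3 in one place: 3-methoxyphenyl in place of pyridin-3-yl on an aromatic carbon. For the measured compounds named here, no measured step bears on this change, and the one step that exists cannot be read. The expectation for compound 4 in this assay therefore rests on the position of compound 3 alone, and the step of a number no higher from compound 3 to compound 4 (the limit leaves the size open) is expected to stay within the scatter. Compound 4 is expected to give about 26000 nM, in the range from 13000 nM to 60000 nM, most likely reported again as a limit.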

Compound 4, half-maximal effective concentration: > 21000 nM
Compound 4 gave a limit, no number; the forecaster's own chance of this, stated with the estimate: 80%; the middle value is on the limit's open side.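

Compound 3 and compound 4 both stand as limits in this assay, not as numbers, and the step between them cannot be read. The compounds shown leave open how 3-methoxyphenyl and pyridin-3-yl compare, and at what concentration, if any, these compounds show an effect.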